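A larger group on the amine nitrogen of compound 3

The source may report more compounds than this note shows. Statements on the series, on what has been measured and on what is new or still open speak of the compounds shown alone.

- Compound 1 `CCOC(=O)C1=C(NN=C(C(C)=O)C(C)=O)Nc2[nH]nc(C)c2C1c1ccc(N(C)C)cc1` gives 17000 nM
- Compound 2 `CCOC(=O)C1=C(N/N=C(\c2ccc([N+](=O)[O-])cc2)N2CCN(c3ccc(F)cc3)CC2)Nc2[nH]nc(C)c2C1c1ccc(N(C)C)cc1` gives 87000 nM
- Compound 3 `CCOC(=O)C1=C(NN=C(C#N)C#N)Nc2[nH]nc(C)c2C1c1ccc(N(C)C)cc1` gives 15200 nM

In a functional assay on HeLa cells (Homo sapiens) for inhibition, read by MTT assay, with a stated time of 48 h (on this read-out higher numbers stand for weaker inhibition and lower numbers for stronger inhibition), compound 3 stands at the low end of these numbers together with compound 1, the two lying within the scatter of each other, while compound 2 shows a clearly higher number. Compound 4 `CCOC(=O)C1=C(N/C=N/c2ccc(C)cc2)Nc2[nH]nc(C)c2C1c1ccc(N(C)C)cc1` has not yet been measured. Its structure departs from that of compound 3 in one place: a group of 9 heavy atoms (8 carbon, 1 nitrogen; one six-membered aromatic ring of carbon only) in place of a group of 6 heavy atoms (3 carbon, 3 nitrogen; no ring), on an amine nitrogen and the entering group brings one six-membered aromatic ring of carbon only.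

Among the measured compounds shown here, one measured step bears directly on this change: a 1.1-fold lower number from compound 1 to compound 3 (0.05 log units; within the scatter) is a swap on the same amine nitrogen, and it stayed within the scatter. Neither group in that step holds a ring, however. A group with rings on that nitrogen appears only in compound 2 at 87000 nM and that group is much larger than the one entering here, which makes it loose guidance. A modest move upward is therefore expected, and a 2.1-fold higher number from compound 3 to compound 4 (0.32 log units; beyond the scatter) is the estimated step in this assay on these grounds. For compound 4 the estimated value is 32000 nM with an expected range from 12000 nM to 85000 nM on this read-out.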

Compound 4, half-maximal inhibitory concentration: 43200 nM
Compound 4: middle estimate off by 1.4-fold (0.13 log units), on the low side; measured number inside the range.
By their numbers in this assay, from the lowest: compounds 3 and 1 (each within the scatter of the next); then compounds 4 and 2 (each within the scatter of the next).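

In this assay, the amine nitrogen whose other neighbours are a double-bonded ring carbon proved responsive to a change of group of moderate size, which the earlier swap between two groups without a ring, a 1.1-fold lower number from compound 1 to compound 3 (0.05 log units; within the scatter), had not shown. Against either of those groups, the entering group with one six-membered aromatic ring of carbon only raised the number beyond the scatter, by a 2.8-fold higher number from compound 3 to compound 4 (0.45 log units; beyond the scatter) and by a 2.5-fold higher number from compound 1 to compound 4 (0.41 log units; beyond the scatter), so compound 1 and compound 3 now stand apart from both ring-bearing compounds, with compound 4 at 43200 nM and compound 2 at 87000 nM within the scatter of each other. Nothing shown accounts for this rise.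

The compounds shown do not separate the presence of the aromatic ring from the other differences between the entering and leaving groups, and a group with a cyclohexyl ring in its place would bear on that point. They also leave open whether a small group on this nitrogen, such as a methyl or an acetyl, would stay level with compound 3 at 15200 nM or move away from it.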